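This account rests on a few compounds, and the source may have more. Where it says the series, first, only, none or still open, it means among the compounds named here.

Of the compounds shown here, two of this small series have been tested in an assay on cells for inhibition of Amine oxidase [flavin-containing] A (Homo sapiens), read by fluorescence and Amplex Red, with a stated time of 15 min; on this read-out higher numbers stand for weaker inhibition and lower numbers for stronger inhibition. Compound 1, with the structure `Cc1ccc2oc(-c3cccc(Br)c3)cc2c1`, gives only a limit of the assay rather than a number: in this assay compound 1 reads > 100000 nM. Within the data shown here, compound 2, with the structure `Cc1ccc2oc(-c3ccccc3Br)cc2c1`, is the one compound with a measured number, since in this assay compound 2 gives 11000 nM. So compound 2 stands as the sole measured value, while the other entry in the table is the limit described by the limit of > 100000 nM in this assay, at which 1 of the 2 values shown sits.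

The next compound, compound 3 with the structure `Cc1ccc2oc(-c3ccccc3)cc2c1`, differs from compound 2 in a single place: hydrogen in place of bromo on an aromatic carbon. The bromine of compound 2 is simply gone, leaving the bare six-membered aromatic ring of carbon only. Among the measured compounds shown here, with no measured step to lean on, the size and direction of the change can only be guessed. The expectation is a modest loss of inhibition, a step of a 2.7-fold higher number from compound 2 to compound 3 (0.44 log units; beyond the scatter), with a fair chance that the assay again returns only a limit. Compound 3 is therefore estimated at 30000 nM, with a range from 6000 nM to 150000 nM.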

Compound 3, half-maximal inhibitory concentration: > 100000 nM
Compound 3: no number, only a limit; the forecaster's own chance of this, stated with the estimate: 35%; middle value at least 3.3-fold (0.52 log units) from the limit.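

In this assay, putting hydrogen in place of bromo on this aromatic carbon, ortho to a large group, gives an at least 9.0-fold higher number from compound 2 to compound 3 (0.95 log units; beyond the scatter), so in this pair the measurable inhibition depends on the bromo being present. On these data alone, the true size of this step stays unknown, because compound 3 gives a limit of the assay and not a number: the limit of > 100000 nM in this assay, at which 2 of the 3 values shown sit. Compound 1 also carries a bromo on its six-membered aromatic ring of carbon only, yet it too gives just a limit of the assay, > 100000 nM, and the step from compound 1 to compound 3 cannot be read.

The compounds shown leave open whether the effect is specific to bromine or whether another group at the same place, such as chloro, methyl, methoxy or an amine, would keep or improve inhibition. They also cannot tell why the bromo matters, and with only compound 2 giving a number, nothing yet shows how much stronger inhibition could become in this series.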